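The source may report more compounds than this note shows. Statements on the series, on what has been measured and on what is new or still open speak of the compounds shown alone.

In an ADME assay on microsomes from liver (Rattus norvegicus) for metabolic stability, with a stated time of 30 min, tested at 1 uM (a lower number here means that less of the compound is left, a higher number that more of the compound is left), compound 1 (`CC[C@@H]1C(=O)N(C)c2cnc(-c3cn[nH]c3-c3ccc(F)cc3F)nc2N1c1cnn(C)c1`) gives 13%, compound 2 (`CCC1C(=O)N(C)c2cnc(-n3ccnc3-c3ccc(F)cc3)nc2N1c1ccc(F)cc1`) gives 11% and compound 3 (`CCC1C(=O)N(C)c2cnc(-n3ccnc3-c3ccc(F)cc3)nc2N1C1CCC(F)(F)C1`) gives 8%, so compound 3 lies within the scatter of both others. Compound 4 (`CCC1C(=O)N(C)c2cnc(-n3ccnc3-c3ccc(F)cc3)nc2N1c1ccc(C#N)cc1`) differs from compound 3 as follows: 4-cyanophenyl in place of 3,3-difluorocyclopentyl on a nitrogen on an aromatic ring in a ring. This puts 4-cyanophenyl in place of 3,3-difluorocyclopentyl on a nitrogen on an aromatic ring in a ring. Among the compounds with values here, the only measured step at this place is a number 3 percentage points lower from compound 2 to compound 3 (within the scatter), and no measured step shows the effect of 4-cyanophenyl itself. No change beyond the scatter is therefore expected in this assay. The expected step is a number 4 percentage points higher from compound 3 to compound 4 (within the scatter). For compound 4 the estimate is 12%, with an expected range of 4% to 26%.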

Compound 4, percent of the compound remaining: 48%
Compound 4: the middle estimate sits 36 percentage points below what was measured, outside the stated range (above it).
By their numbers in this assay, from the lowest: compounds 3, 2 and 1 (each within the scatter of the next); then compound 4.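

In this assay, the group on this nitrogen can clearly shift the number: a number 40 percentage points higher from compound 3 to compound 4 (beyond the scatter), whereas the earlier step here stayed within the scatter. A phenyl ring alone does not account for this, since the exchange of a single substituent gives a number 37 percentage points higher from compound 2 to compound 4 (beyond the scatter). Nothing measured here bears on the reason for this rise.

Going by these compounds, it remains open whether the nitrile is unique in this respect or whether a carboxamide, a methoxy group or a trifluoromethyl group on the same phenyl ring would behave similarly. On these data alone, whether 4-cyanophenyl has the same effect on the core of compound 1 also remains open.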